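This account rests on a few compounds, and the source may have more. Where it says the series, first, only, none or still open, it means among the compounds named here.

In a functional assay on K562 cells (Homo sapiens) for cytotoxicity, read by sulforhodamine B assay (on this read-out higher numbers stand for weaker inhibition of growth and lower numbers for stronger inhibition of growth), compound 1 `COc1ccc(/C=N\NC(=S)NC(C)(C)CCC[C@](C)(O)[C@@H]2CC=C(C)CC2)cc1` gives 220 nM. This lies within the scatter of compound 3 `CC1=CC[C@@H]([C@@](C)(O)CCCC(C)(C)NC(=S)N/N=C\c2ccccc2Cl)CC1` at 150 nM and far from compound 2 `CC1=CC[C@@H]([C@@](C)(O)CCCC(C)(C)NC(=S)N/N=C\c2ccc([N+](=O)[O-])cc2)CC1` at 4220 nM. Compound 4 `CC1=CC[C@@H]([C@@](C)(O)CCCC(C)(C)NC(=S)N/N=C\c2cccc(Cl)c2)CC1` differs from compound 1 by one change: 3-chlorophenyl in place of 4-methoxyphenyl on a carbon with a double bond to nitrogen, with 3-chlorophenyl in place of 4-methoxyphenyl on a carbon with a double bond to nitrogen. Going by the values given here, the closest precedent is a 1.5-fold lower number from compound 1 to compound 3 (0.17 log units; within the scatter), where 2-chlorophenyl enters at the same place. The large 19-fold higher number from compound 1 to compound 2 (1.28 log units; beyond the scatter) comes with nitro in place of methoxy, and compound 4 carries no nitro. On the precedent of compound 3, no step beyond the scatter is expected in this assay. The estimated step is a 1.2-fold lower number from compound 1 to compound 4 (0.09 log units; within the scatter). Compound 4 is expected at 180 nM, with an estimated range of 70 nM to 500 nM.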

Compound 4, concentration for 50% growth inhibition: 30 nM
For compound 4 the middle estimate is 6.0-fold (0.78 log units) above the measured one; measured number outside the range, below it.
By their numbers in this assay, from the lowest: compound 4; then compounds 3 and 1 (each within the scatter of the next); then compound 2.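

With 3-chlorophenyl in place of 2-chlorophenyl on the same carbon, this assay shows a 5.0-fold lower number from compound 3 to compound 4 (0.70 log units; beyond the scatter), so where the chlorine sits on the phenyl ring matters, which compound 3 alone could not show. The same group gives a 7.3-fold lower number from compound 1 to compound 4 (0.87 log units; beyond the scatter) and a 140-fold lower number from compound 2 to compound 4 (2.15 log units; beyond the scatter), leaving compound 4 with the lowest number of the four compounds. No measurement shown here accounts for this difference between the two chlorophenyl groups. As far as these compounds go, it remains open whether 4-chlorophenyl, 3-bromophenyl or 3-methoxyphenyl would behave like 3-chlorophenyl at this place.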